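A few compounds are considered here, and "the series" means these few. Any claim that something is new, unique, unknown or untested is made for them only; others in the source may bear on it.

Among the compounds with values here, compound 1 `O=C(Nc1cccc(/C=C/C(=O)c2nc3ccccc3[nH]2)c1)c1cccc(Cl)c1` is measured in a functional assay on MCF7 cells (Homo sapiens) for antiproliferative activity, read by MTT assay, with a stated time of 48 h (on this read-out higher numbers stand for weaker inhibition and lower numbers for stronger inhibition), where compound 1 gives 7840 nM, the lowest of the two numbers so far. Its companion, compound 2 `COc1ccc(C(=O)Nc2cccc(/C=C/C(=O)c3nc4ccccc4[nH]3)c2)cc1`, gives 20100 nM in this assay; the step of a 2.6-fold higher number from compound 1 to compound 2 (0.41 log units; beyond the scatter) comes from swapping the ring on the carbonyl. Compound 3 `O=C(/C=C/c1cccc(NS(=O)(=O)c2ccccc2Cl)c1)c1nc2ccccc2[nH]1` changes compound 1 differently: (2-chlorophenyl)sulfonyl in place of (3-chlorophenyl)carbonyl on a nitrogen on an aromatic ring. Within the data shown here, no measured step covers a carbonyl-to-sulfonyl exchange, so only the modest size of the one known step guides the expectation. Compound 3 is therefore estimated at 10000 nM, within 4000 nM to 25000 nM, a step of a 1.3-fold higher number from compound 1 to compound 3 (0.11 log units; within the scatter) that is expected to stay near the scatter.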

Compound 3, half-maximal inhibitory concentration: 4280 nM
Beside the measured number, compound 3's estimate is 2.3-fold (0.37 log units) above it, and the stated range covers the measured number.
By their numbers in this assay, from the lowest: compounds 3 and 1 (each within the scatter of the next); then compound 2.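

In this assay the nitrogen on the aromatic ring can carry (2-chlorophenyl)sulfonyl in place of (3-chlorophenyl)carbonyl with a 1.8-fold lower number from compound 1 to compound 3 (0.26 log units; within the scatter) and so the carbonyl link is not required for this level of activity. Set against (4-methoxyphenyl)carbonyl, the same sulfonyl group gives a 4.7-fold lower number from compound 2 to compound 3 (0.67 log units; beyond the scatter) and this step is clearer. No evidence explains these differences. Still open, from the compounds shown here alone, is how much depends on the sulfonyl link and how much on the position of the chlorine, since both change together, and how an amine or a carboxylic acid on that ring would read out.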